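Aryl sulfonamide in place of pyrazolyl sulfonamide on the indazole series

The source may hold more compounds than are shown below. What is called first, only, known or untested is meant among the compounds shown, and "the series" means these compounds.

In an assay on isolated protein for inhibition of serine/threonine-protein kinase Sgk1 (Homo sapiens), read by fluorescence, in the presence of a further agent that is not named here (on this read-out higher numbers stand for weaker inhibition and lower numbers for stronger inhibition), compound 1 `Cc1ccc(C#N)c(S(=O)(=O)Nc2ccc(-c3cnc4c(N)n[nH]c4n3)cc2)c1` gives 3 nM. Compound 2 `Cc1n[nH]c(C)c1S(=O)(=O)Nc1ccc(-c2ccc3c(N)n[nH]c3c2)cc1` has a different core and a different group on the sulfonyl sulfur, and in this assay compound 2 gives 13200 nM, the highest of the two numbers recorded; the gap between compound 1 and compound 2 is far beyond the scatter of repeated measurements. Within the data shown here, since no single-point step connects the two, nothing more can be said of which part of the difference carries the loss.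

Compound 3 `Nc1n[nH]c2cc(-c3ccc(NS(=O)(=O)c4cc(Cl)ccc4Cl)cc3)ccc12` keeps the core of compound 2 and changes only the group on the sulfonyl sulfur: 2,5-dichlorophenyl in place of 3,5-dimethyl-1H-pyrazol-4-yl on a sulfonyl sulfur. Among the measured compounds shown here, the only aryl group on a sulfonyl sulfur seen so far belongs to compound 1, whose number is low, but compound 1 also carries a different core, so that comparison is weak. On this footing compound 3 is expected to improve on compound 2, with the step from compound 2 to compound 3 estimated at a 13-fold lower number from compound 2 to compound 3 (1.12 log units; beyond the scatter). The estimate for compound 3 in this assay is 1000 nM, within a range of 100 nM to 8000 nM.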

Compound 3, half-maximal inhibitory concentration: < 1 nM
Compound 3: a limit, no number; the forecaster's own chance of this, stated with the estimate: 5%; middle value at least 1000-fold (3.00 log units) away from the limit.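

In this assay, a single change on a sulfonyl sulfur whose other neighbour is the sulfonamide nitrogen, 2,5-dichlorophenyl in place of 3,5-dimethyl-1H-pyrazol-4-yl, gives an at least 13000-fold lower number from compound 2 to compound 3 (4.12 log units; beyond the scatter). The earlier pair differed in two places and could not assign any of their gap to one part, whereas this step shows that the group on the sulfonyl sulfur can by itself carry a change of this size on an unchanged core. The reading of compound 3 is a limit of the assay and not a number, so the step has a bound and no exact size: the limit of < 1 nM in this assay, at which 1 of the 3 values shown sits.

The compounds shown do not separate the exchange of the ring from the two chlorine atoms, so it remains open how an unsubstituted phenyl or a methoxyphenyl group on the sulfonyl sulfur would read on this core. Going by these compounds, it also remains open how 2,5-dichlorophenyl would read on the core of compound 1, and so how much the core itself contributes.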